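Hydroxymethyl in Place of Carboxy: One Expected Step

The source may hold more compounds than are shown below. What is called first, only, known or untested is meant among the compounds shown, and "the series" means these compounds.

compound 1 `O=C(NO)c1ccc(-c2cn([C@H]3C[C@H](C(=O)O)N(CCCc4ccccc4)C3)nn2)cc1`: < 10%
compound 2 `O=C(NO)c1ccc(-c2cn([C@@H]3C[C@H](CO)N(Cc4ccccc4)C3)nn2)cc1`: 14%

In an assay on Sf9 cells for inhibition of histone deacetylase 11 (Homo sapiens), read by fluorescence, tested at 0.5 uM (a lower number here means less inhibition, a higher number more inhibition at the concentration tested (going by the name of the read-out)), compound 1 gives only a limit, < 10%, not a number; (the limit of < 10% in this assay, at which 1 of the 2 values shown sits). In this assay compound 2 gives 14%. Compound 3, `O=C(NO)c1ccc(-c2cn([C@H]3C[C@H](CO)N(CCCc4ccccc4)C3)nn2)cc1`, has not yet been measured there. It differs from compound 1 by hydroxymethyl in place of carboxy on a saturated ring carbon. Within the data shown here, no measured pair shows this change on its own, so the step of a number at least 2 percentage points higher from compound 1 to compound 3 (that floor lies within the scatter) is expected to be small, within the usual scatter, in no clear direction. For compound 3 the estimate is 12%, expected to lie between 0% and 30%.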

Compound 3, a percentage reported as inhibition, at one concentration (the size of the read-out at that concentration, not a potency): 18%
Estimate against measurement, compound 3: 6 percentage points below, and the stated range covers the measured number.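

In this assay, hydroxymethyl in place of carboxy on a saturated ring carbon, next to the ring nitrogen, gives a number at least 8 percentage points higher from compound 1 to compound 3 (that floor lies within the scatter). Among these compounds, this is the first reading of this change on its own, with the 3-phenylpropyl group held constant. Compound 1 gives < 10%, which is a limit and not a number, so the step is only a floor because of where compound 1 stands: the limit of < 10% in this assay, at which 1 of the 3 values shown sits.

As far as these compounds go, whether an aminomethyl group or a longer chain ending in hydroxyl on this ring carbon would read differently in this assay stays open.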